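A few compounds are considered here, and "the series" means these few. Any claim that something is new, unique, unknown or untested is made for them only; others in the source may bear on it.

Of the compounds shown here, three on a shared core have been tested in an ADME assay on GES1 cells (Homo sapiens) for inhibition, read by MTT assay, with a stated time of 72 h; a lower number here means a stronger inhibitor, a higher number a weaker inhibitor. Compound 1 `Cc1cc(Nc2cc(-c3ccccc3)[nH]n2)n2nc(SCc3c(Cl)cccc3Cl)nc2n1` gives 39600 nM. Compound 2 `Cc1cc(Nc2cc(-c3ccccc3)[nH]n2)n2nc(SCc3cccc(Br)c3)nc2n1` reaches only a limit of the assay, > 50000 nM. Compound 3 `CCCSc1nc2nc(C)cc(Nc3cc(-c4ccccc4)[nH]n3)n2n1` also stands at a limit of the assay, > 50000 nM. This is the limit of > 50000 nM in this assay, at which 2 of the 3 values shown sit. The measured steps are an at least 1.2-fold higher number from compound 1 to compound 2 (0.10 log units; that floor lies within the scatter) and an at least 1.2-fold higher number from compound 1 to compound 3 (0.10 log units; that floor lies within the scatter), while a step that the two limits leave unreadable from compound 2 to compound 3. Compound 4 `C=CCSc1nc2nc(C)cc(Nc3cc(-c4ccccc4)[nH]n3)n2n1` differs from compound 3 by vinyl in place of ethyl on a saturated chain carbon bound to a sulfur. Going by the values given here, none of the measured steps exchanges ethyl for vinyl, so none bears directly on this change, and the values around compound 3 offer no readable step at all. Compound 4 is therefore expected to show no step beyond the scatter, the expected step being a step that the limit leaves unreadable from compound 3 to compound 4. Compound 4 is estimated at 70000 nM, between 30000 nM and 200000 nM.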

Compound 4, half-maximal inhibitory concentration: > 50000 nM
Compound 4 was reported as a limit; the forecaster's own chance of this, stated with the estimate: 80%; the middle value is on the limit's open side.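

With vinyl in place of ethyl on a saturated chain carbon bound to a sulfur, compound 4 also stops at a limit in this assay, so the steps from compound 3 and from compound 2 to compound 4 cannot be read. Going by these compounds alone, the one readable step is an at least 1.2-fold higher number from compound 1 to compound 4 (0.10 log units; that floor lies within the scatter). Compound 4 thus adds a third compound to those at the limit: the limit of > 50000 nM in this assay, at which 3 of the 4 values shown sit.

Going by these compounds, how far these compounds lie past the limit stays open. So does whether an amine or a carboxylic acid on that chain carbon would give a measurable number.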